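The source may report more compounds than this note shows. Statements on the series, on what has been measured and on what is new or still open speak of the compounds shown alone.

Working notes on the arylurea hydrazone series. Compound 1 `CN(C)CCn1cnnc1-c1cc(Oc2ccc(NC(=O)N/N=C/c3ccc(Cl)cc3Cl)cc2F)ccn1` carries a 2,4-dichlorophenyl on the carbon with a double bond to nitrogen; in a functional assay on U-87MG ATCC cells (Homo sapiens) for cytotoxicity, read by MTT assay, with a stated time of 72 h (on this read-out lower numbers stand for stronger inhibition and higher numbers for weaker inhibition), compound 1 gives 2330 nM. Compound 2 `CN(C)CCn1cnnc1-c1cc(Oc2ccc(NC(=O)N/N=C/c3ccc(O)c(Br)c3)cc2F)ccn1` instead carries a 3-bromo-4-hydroxyphenyl, and in this assay compound 2 gives 12400 nM, a step of a 5.3-fold higher number from compound 1 to compound 2 (0.73 log units; beyond the scatter). Compound 3 `CN(C)CCn1cnnc1-c1cc(Oc2ccc(NC(=O)N/N=C/c3ccc(O)c(O)c3)cc2F)ccn1` carries a 3,4-dihydroxyphenyl. In this assay compound 3 reaches only the limit of the assay, > 100000 nM, so no number is known for it. The steps to it are therefore open-ended: an at least 42-fold higher number from compound 1 to compound 3 (1.63 log units; beyond the scatter) and an at least 8.0-fold higher number from compound 2 to compound 3 (0.90 log units; beyond the scatter), both bounded only because the limit of > 100000 nM in this assay, at which 1 of the 3 values shown sits, holds compound 3. Compound 3 thus stands at the weak end of the three, and compound 1 at the strong end.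

Compound 4 `CN(C)CCn1cnnc1-c1cc(Oc2ccc(NC(=O)N/N=C/c3cc(Br)c(O)c(Br)c3)cc2F)ccn1` differs from compound 3 by 3,5-dibromo-4-hydroxyphenyl in place of 3,4-dihydroxyphenyl on a carbon with a double bond to nitrogen. The change runs opposite to the hydroxy-for-bromo swap of an at least 8.0-fold higher number from compound 2 to compound 3 (0.90 log units; beyond the scatter) and adds a second bromine, so a return toward the number of compound 2 is the working expectation, with the direction set by that step. Compound 4 is expected to give 8000 nM in this assay, with a range of 2500 nM to 30000 nM. This expected step, an at least 12-fold lower number from compound 3 to compound 4 (1.09 log units; beyond the scatter), cannot be sized precisely against a limit.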

Compound 4, half-maximal inhibitory concentration: > 100000 nM
Compound 4 was reported as a limit; the forecaster's own chance of this, stated with the estimate: 15%; middle value at least 12-fold (1.09 log units) from the limit.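

In this assay, bromo in place of hydrogen on an aromatic carbon of the 3-bromo-4-hydroxyphenyl does not hold the number of compound 2 but moves it to the weak side, giving an at least 8.0-fold higher number from compound 2 to compound 4 (0.90 log units; beyond the scatter). The 3,5-dibromo-4-hydroxyphenyl also falls far behind the 2,4-dichlorophenyl on the carbon with a double bond to nitrogen, giving an at least 42-fold higher number from compound 1 to compound 4 (1.63 log units; beyond the scatter), so a halogen on this ring does not by itself give a readable number: compound 2 has one, compound 4 does not, and compound 3 without bromine has none either. The step between compound 3 and compound 4 cannot be read, and no order can be set between 3,4-dihydroxyphenyl and 3,5-dibromo-4-hydroxyphenyl, as both compounds rest on one limit: the limit of > 100000 nM in this assay, at which 2 of the 4 values shown sit.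

The compounds shown leave open whether the hydroxy on the ring is what separates compound 2 and compound 4 from compound 1. A 3,5-dibromo-4-methoxyphenyl or a 4-aminophenyl at this place would speak to that question, and the data here give no reading for either group.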